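The compounds below may be only part of what the source reports. "The series", "measured", "known", "first", "only" and "open" are said of these compounds alone.

Compounds measured so far:
- Compound 1, `Cc1nc(N(C)c2ccc([Se]C#N)c(Cl)c2)c2ccccc2n1`, gives 12 nM in a functional assay on HCT-116 cells (Homo sapiens) for inhibition, read by MTT assay, with a stated time of 48 h; a higher number here means a weaker inhibitor, a lower number a stronger inhibitor.
- Compound 2, `COc1ccc(N(C)c2nc(C)nc3ccccc23)cc1C(=O)OCCCCC[Se]C#N`, gives 551 nM in this assay.
- Compound 3, `COc1ccc(N(C)c2nc(C)nc3ccccc23)cc1C(=O)OCC[Se]C#N`, gives 951 nM in this assay.

Compound 3 has the highest of the three numbers. Its nearest neighbour is compound 2, whose number is lower by a step that falls within the scatter; compound 1 is furthest away, with a number lower by a margin well beyond the scatter.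

The unmeasured compound 4, `COc1ccc(N(C)c2nc(C)nc3ccccc23)cc1OCCC[Se]C#N`, differs from compound 3 in a single place: a group of 7 heavy atoms (4 carbon, 1 nitrogen, 1 oxygen, 1 selenium; no ring) in place of a group of 8 heavy atoms (4 carbon, 1 nitrogen, 2 oxygen, 1 selenium; no ring), on an aromatic carbon. The substituent sits on an aromatic carbon of a six-membered aromatic ring of carbon only, ortho to a methoxy group and meta to a large group.

For the measured compounds named here, one measured step bears on this change. Between compound 2 and compound 3 a shorter chain on the same position gave a 1.7-fold higher number from compound 2 to compound 3 (0.24 log units; within the scatter), a step within the scatter. The move from compound 3 to compound 4 again keeps the selenocyanate-bearing chain on the same aromatic carbon and changes only its link and length, so the expected step is again small; its direction is not determined by the data. Compound 4 is therefore expected to give about 800 nM in this assay, within a range of 250 nM to 2500 nM, which corresponds to an expected step of a 1.2-fold lower number from compound 3 to compound 4 (0.08 log units; within the scatter).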

Compound 4, half-maximal inhibitory concentration: 852 nM
The estimate for compound 4 lay 1.1-fold (0.03 log units) below the measured number, and the stated range covers the measured number.
By their numbers in this assay, from the lowest: compound 1; then compounds 2, 4 and 3 (each within the scatter of the next).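

In this assay, the change on this aromatic carbon, ortho to a methoxy group, gives a 1.1-fold lower number from compound 3 to compound 4 (0.05 log units; within the scatter). The earlier step, a 1.7-fold higher number from compound 2 to compound 3 (0.24 log units; within the scatter), altered only the chain and kept the ester link, whereas this one gives up the carbonyl group, going from 1 double bond and 3 hydrogen-bond acceptors in the group to no double bond and 2 acceptors, and the number still stays within the scatter, so among these compounds neither change at this position separates the values. No measurement shown here offers a cause for this.

On these data alone, what remains open is whether the ether link would tolerate a longer chain as the ester did, and whether an amide or an amine link, or a thiocyanate in place of the selenocyanate, would hold the number in this assay. Compound 1, at 12 nM, differs from the others in more than one place, so its value cannot be assigned to any single feature, and a compound with the selenocyanate-bearing chain replaced by a selenocyanate directly on the ring would be needed to connect the two.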